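The source may hold more compounds than are shown below. What is called first, only, known or untested is meant among the compounds shown, and "the series" means these compounds.

Going by the values given here, in a functional assay on a cell-free system (plasma, Oryctolagus cuniculus) for inhibition of platelet-activating factor acetylhydrolase (Homo sapiens), tested at 100 nM (on this read-out higher numbers stand for more inhibition at the one concentration tested (going by the name of the read-out) and lower numbers for less inhibition), compound 2 `CCCCCCCCN(C)C(=O)Cn1cc(Cc2cnc(O)nc2)c(=O)nc1SCc1ccc(F)cc1` gives 34%, the higher of the two numbers measured so far. Its companion compound 1 `CCCCCCCCN(C)C(=O)Cn1cc(Cc2cnc(OCc3ccccc3)nc2)c(=O)nc1SCc1ccc(F)cc1` gives 8% in this assay, and the step of a number 26 percentage points higher from compound 1 to compound 2 (beyond the scatter) arises from hydrogen in place of benzyl on an oxygen on an aromatic ring. Compound 3 `CCCCCCCCCCCCN(C)C(=O)Cn1cc(Cc2cnc(O)nc2)c(=O)nc1SCc1ccc(F)cc1` has not yet been measured; it differs from compound 2 by butyl in place of hydrogen on a saturated chain carbon, eight bonds along the chain from an amide-type nitrogen. Among the compounds with values here, no measured step touches this kind of change: the only step recorded alters a different part of the molecule, so it offers no guide to how a longer chain on that carbon behaves. Nothing shown therefore gives a reason to expect a move beyond the scatter in either direction, and the step of a number 6 percentage points higher from compound 2 to compound 3 (within the scatter) is expected to be small. Compound 3 is accordingly estimated to give 40% in this assay, most likely between 15% and 70%.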

Compound 3, a percentage reported as inhibition, at one concentration (the size of the read-out at that concentration, not a potency): 39%
Beside the measured number, compound 3's estimate is 1 percentage points above it, within the range that was stated.
By their numbers in this assay, from the lowest: compound 1; then compounds 2 and 3 (each within the scatter of the next).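

In this assay, butyl in place of hydrogen on a saturated chain carbon, eight bonds along the chain from an amide-type nitrogen, gives a number 5 percentage points higher from compound 2 to compound 3 (within the scatter). Going by these compounds alone, this is the first look at the chain, since the earlier step concerned only the group on the oxygen, and it shows that adding butyl here makes no change that can be told from ordinary assay scatter. Nothing shown bears on why this change leaves the number within the scatter.

The compounds shown leave open whether a still longer chain, or an amine or a carboxylic acid on this same carbon, would move the number beyond the scatter. They also leave open whether butyl at this carbon would give a similar step with benzyl on the oxygen, as in compound 1.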